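This account rests on a few compounds, and the source may have more. Where it says the series, first, only, none or still open, it means among the compounds named here.

In a functional assay on HepG2 cells (Homo sapiens) for antiproliferative activity, read by XTT assay, with a stated time of 72 h (a lower number here means a stronger inhibitor, a higher number a weaker inhibitor), compound 2 `COc1ncnc2c1c(I)cn2[C@@H]1O[C@H](CO)[C@@H](O)[C@H]1O` gives only a limit, > 20000 nM. Compound 1 `Nc1nc(N)c2c(-c3ccsc3)cn([C@@H]3O[C@H](CO)[C@@H](O)[C@H]3O)c2n1` likewise reaches only the limit > 20000 nM. Compound 3 `Nc1nc2c(c(-c3ccccc3)cn2[C@@H]2O[C@H](CO)[C@@H](O)[C@H]2O)c(=O)[nH]1` also stops at the limit > 20000 nM. Compound 2 thus stands exactly where every value shown stands, on (the limit of > 20000 nM in this assay, at which 3 of the 3 values shown sit). Compound 4 `COc1ncnc2c1c(-c1cccs1)cn2[C@@H]1O[C@H](CO)[C@@H](O)[C@H]1O` differs from compound 2 by a single change: thiophen-2-yl in place of iodo on an aromatic carbon. Within the data shown here, no measured pair separated by one change exists to gauge this step in this assay, and with all three values resting on (the limit of > 20000 nM in this assay, at which 3 of the 3 values shown sit), no step beyond the usual scatter is expected in either direction. Compound 4 is therefore estimated to give 20000 nM, with a range from 5000 nM to 80000 nM. The estimated step, a number no higher from compound 2 to compound 4 (the limit leaves the size open), is expected to amount to no real change.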

Compound 4, half-maximal inhibitory concentration: 13900 nM
Beside the measured number, compound 4's estimate is 1.4-fold (0.16 log units) above it, and the stated range covers the measured number.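

In this assay, compound 4 gives a real number, 13900 nM, with thiophen-2-yl at this aromatic carbon. On these data alone, the change gives an at least 1.4-fold lower number from compound 2 to compound 4 (0.15 log units; that floor lies within the scatter), so its true size stays unknown and no real gain over iodo can be claimed. The other compounds offer little to compare with: the limit of > 20000 nM in this assay, at which 3 of the 4 values shown sit.

As far as these compounds go, whether an amine or a longer chain on this same carbon would give a clearly lower number remains open. So does whether any other five-membered aromatic ring here would match thiophen-2-yl.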